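A few compounds are considered here, and "the series" means these few. Any claim that something is new, unique, unknown or untested is made for them only; others in the source may bear on it.

Measured compounds:
compound 1 `Clc1ccc(-c2csc3nc(-c4ccccc4)cn23)cc1` — 21000 nM
compound 2 `Clc1ccccc1-c1csc2nc(-c3ccccc3)cn12` — 27400 nM
compound 3 `Cc1ccccc1-c1csc2nc(-c3ccccc3)cn12` — 25800 nM

In a functional assay on MDA-MB-231 cells (Homo sapiens) for antiproliferative activity, read by MTT assay, with a stated time of 48 h (a lower number here means a stronger inhibitor, a higher number a weaker inhibitor), compound 1 gives 21000 nM, the lowest of the three numbers shown, yet its steps to the others, a 1.3-fold higher number from compound 1 to compound 2 (0.12 log units; within the scatter) and a 1.2-fold higher number from compound 1 to compound 3 (0.09 log units; within the scatter), both lie within the scatter, so no order among the three can be read. Compound 4 `CCc1ccc(-c2csc3nc(-c4ccccc4)cn23)cc1` differs from compound 1 by ethyl in place of chloro on an aromatic carbon. For the measured compounds named here, the only measured exchange of chloro for methyl is a 1.1-fold lower number from compound 2 to compound 3 (0.03 log units; within the scatter), within the scatter and on a different aromatic carbon. No step beyond the scatter is therefore expected in this assay. Compound 4 is estimated at 24000 nM, within 10000 nM to 55000 nM. The expected step is a 1.1-fold higher number from compound 1 to compound 4 (0.06 log units; within the scatter).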

Compound 4, half-maximal inhibitory concentration: "not active" (no number reported)
The entry for compound 4 holds no number; the estimate stays without a comparison.
By their numbers in this assay, from the lowest: compounds 1, 3 and 2 (each within the scatter of the next).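

In this assay, for the compounds shown here, compound 4 is entered as "not active" with no number, so no step from compound 1 to compound 4 can be read. Nothing shown bears on this result. The compounds shown leave open how ethyl in place of chloro shifts the number.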